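The source may report more compounds than this note shows. Statements on the series, on what has been measured and on what is new or still open speak of the compounds shown alone.

Measured so far:
- compound 1 `Cc1nc(N2CCCCC2)c2nnn(-c3ccc(C(C)C)cc3Br)c2n1`: 46 nM
- compound 2 `COCC(COC)Nc1nc(C)nc2c1nnn2-c1ccc(C(C)C)cc1Br`: 10.3 nM

Both numbers come from an in vitro assay on 293-EBNA cells for binding affinity to corticotropin-releasing factor receptor 1 (Homo sapiens); on this read-out higher numbers stand for weaker inhibition and lower numbers for stronger inhibition. Going by the values given here, compound 2 stands at the lower of the two, and the single step that exists, a 4.5-fold lower number from compound 1 to compound 2 (0.65 log units; beyond the scatter), shows what swapping the ring amine for an open-chain ether-bearing amine did to the read-out.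

Compound 3 `CCN(CC)c1nc(C)nc2c1nnn2-c1ccc(C(C)C)cc1Br` has not been measured yet. Its change from compound 2 is diethylamino in place of (2-methoxy-1-(methoxymethyl)ethyl)amino on an aromatic carbon. The new group is an open-chain amine, as in compound 2, yet it carries no ether oxygens and, like the piperidin-1-yl of compound 1, no hydrogen-bond donor; it is also smaller than either of those two groups. The step from compound 1 to compound 2 is the only one that bears on this position, and it was modest. Among the compounds with values here, with only that step to go on, and with compound 3 lying structurally between compound 1 and compound 2, a modest rise in this assay is expected, a 2.4-fold higher number from compound 2 to compound 3 (0.39 log units; beyond the scatter), though a number within the scatter of compound 2 would not surprise. Compound 3 is therefore estimated at 25 nM, with a likely range from 8 nM to 80 nM.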

Compound 3, inhibition constant: 25.3 nM
Beside the measured number, compound 3's estimate is 1.0-fold (0.01 log units) below it; low and high end bracket the measured number.
By their numbers in this assay, from the lowest: compound 2; then compounds 3 and 1 (each within the scatter of the next).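

Replacing the ether-bearing amine with diethylamino gives a 2.5-fold higher number from compound 2 to compound 3 (0.39 log units; beyond the scatter) in this assay, so being an open-chain amine is not enough to keep the lowest number of the set, which stays with the (2-methoxy-1-(methoxymethyl)ethyl)amino group. The comparison with the ring amine gives a 1.8-fold lower number from compound 1 to compound 3 (0.26 log units; within the scatter), so diethylamino and piperidin-1-yl cannot be told apart here, and among these two groups, closing the amine into a ring makes no measurable difference. No supporting measurement is available to explain why the ether-bearing group stands apart.

The group that leaves differs from diethylamino in several ways at once: its heavy-atom count, its hydrogen-bond donor and its hydrogen-bond acceptors all change together, so these three compounds cannot show which of those differences matters. Pentan-3-ylamino, which keeps the amine hydrogen without the ether oxygens, and bis(2-methoxyethyl)amino, which keeps the ether oxygens without that hydrogen, are the kinds of groups that could pull those features apart at this position.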